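The source may hold more compounds than are shown below. What is called first, only, known or untested is meant among the compounds shown, and "the series" means these compounds.

Compound 1 `NC(=O)c1cccc(Cn2cc(-c3ccc4cn[nH]c4c3)ccc2=O)c1`, compound 2 `O=c1ccc(-c2n[nH]c3ncc(Br)cc23)cn1Cc1ccccc1` and compound 3 `Cn1ncc2ccc(-c3ccc(=O)n(Cc4ccccc4)c3)cc21` have been measured in an assay for inhibition of MAP kinase-interacting serine/threonine-protein kinase 1 (Homo sapiens), read by luminescence and ADP-Glo, with a stated time of 2 h; a lower number here means a stronger inhibitor, a higher number a weaker inhibitor. Compound 1 gives 388 nM, and compound 2 gives 56 nM. For compound 3 the reading is a limit of the assay, > 2000 nM, that is the limit of > 2000 nM in this assay, at which 1 of the 3 values shown sits. Of the two numbers, compound 1 holds the higher one; compound 2 sits lower, beyond the scatter. Compound 4 `O=c1ccc(-c2ccc3cn[nH]c3c2)cn1Cc1cccc(C(F)(F)F)c1` differs from compound 1 by trifluoromethyl in place of carbamoyl on an aromatic carbon. Among the compounds with values here, no step between measured compounds covers this change, so no direction can be read from the numbers; the expected step in this assay is small, at most about the scatter, in either direction. Compound 4 is therefore expected to give 500 nM, between 150 nM and 1600 nM. This amounts to an expected 1.3-fold higher number from compound 1 to compound 4 (0.11 log units; within the scatter).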

Compound 4, half-maximal inhibitory concentration: 40 nM
Compound 4: middle estimate off by 13-fold (1.10 log units), on the high side; measured number outside the range, below it.
By their numbers in this assay, from the lowest: compounds 4 and 2 (each within the scatter of the next); then compound 1. At a limit, above all of these: compound 3.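

Replacing carbamoyl with trifluoromethyl on this aromatic carbon gives a 9.7-fold lower number from compound 1 to compound 4 (0.99 log units; beyond the scatter) in this assay, so the group at this position clearly affects the reading. The carbamoyl, with its hydrogen-bond donor and acceptor, is also not required for a number of this size. Nothing measured here accounts for the size of this step.

From the compounds shown here alone, with only these two groups compared here, it remains open whether the step comes from losing carbamoyl or from gaining trifluoromethyl. Going by these compounds, how a plain hydrogen, a methyl, a nitrile or an amine would read on this carbon also remains open.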